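Dimethylamino for hydroxy on the side chain

The source may report more compounds than this note shows. Statements on the series, on what has been measured and on what is new or still open speak of the compounds shown alone.

Compound 3 (`COC1=CC(=O)c2ncnc(NCCO)c2C1=O`) gives 1.78 ug/mL in a functional assay on L1210 cells (Mus musculus) for inhibition (a higher number here means a weaker inhibitor, a lower number a stronger inhibitor), and is the weakest inhibitor of the three measured, with both gaps beyond the scatter. Compound 1 (`CCCC(=O)OCCNc1ncnc2c1C(=O)C(OC)=CC2=O`) stands at 0.85 ug/mL and compound 2 (`CCN(CC)CCNc1ncnc2c1C(=O)C(OC)=CC2=O`) at 0.281 ug/mL in the same series. Compound 4 (`COC1=CC(=O)c2ncnc(NCCN(C)C)c2C1=O`) carries dimethylamino in place of hydroxy on a saturated chain carbon, two bonds along the chain from a nitrogen on an aromatic ring. For the measured compounds named here, the closest precedent is the diethylamino-to-hydroxy change (a 6.3-fold higher number from compound 2 to compound 3 (0.80 log units; beyond the scatter)), read here in reverse. The ester comparison (a 2.1-fold higher number from compound 1 to compound 3 (0.32 log units; beyond the scatter)) bears on it less directly. On these data alone, a lower number of similar or somewhat smaller size is therefore expected, though dimethylamino itself is untested. The expected change is a modest one (a 4.5-fold lower number from compound 3 to compound 4 (0.65 log units; beyond the scatter)). Compound 4 is estimated at 0.4 ug/mL (expected range 0.15 ug/mL to 1.1 ug/mL).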

Compound 4, half-maximal inhibitory concentration: 0.316 ug/mL
Compound 4: middle estimate off by 1.3-fold (0.10 log units), on the high side; low and high end bracket the measured number.
By their numbers in this assay, from the lowest: compounds 2 and 4 (each within the scatter of the next); then compound 1; then compound 3.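

Dimethylamino at this place on the chain gives a second amine with a large gain over the free hydroxy (a 5.6-fold lower number from compound 3 to compound 4 (0.75 log units; beyond the scatter)), and it also stands clear of the ester (a 2.7-fold lower number from compound 1 to compound 4 (0.43 log units; beyond the scatter)). Exchanging diethylamino for dimethylamino leaves the number within the scatter (a 1.1-fold higher number from compound 2 to compound 4 (0.05 log units; within the scatter)), so the two amines are not separated in this assay. Nothing measured here accounts for the gain of either amine over the hydroxy or the ester. Still open, on these data alone, is whether a primary amine or a ring amine such as morpholine would hold the same level. A longer chain in place of 2-(dimethylamino)ethyl also remains to be read.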